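Replacing a trifluoromethylphenyl amide substituent with hydroxyphenyl

A few compounds are considered here, and "the series" means these few. Any claim that something is new, unique, unknown or untested is made for them only; others in the source may bear on it.

Compound 1, `O=C(Nc1ccc(C(F)(F)F)cc1)C1c2ccccc2CCN1C(=O)c1ccc(Cl)cc1`: 4200 nM in a functional assay on NUGC-3 cells (Homo sapiens) for inhibition, read by sulforhodamine B assay, with a stated time of 48 h; a higher number here means a weaker inhibitor of growth, a lower number a stronger inhibitor of growth.
Compound 2, `O=C(Nc1cccc(C(F)(F)F)c1)c1nccc2ccccc12`: > 10000 nM, a limit of the assay in this assay.
Compound 3, `O=C(Nc1ccc(Cl)cc1)c1nccc2ccccc12`: > 10000 nM, a limit of the assay in this assay.

Going by the values given here, compound 1 is the only compound of the three with a measured number in this assay; the other two sit at a limit, as noted in the limit of > 10000 nM in this assay, at which 2 of the 3 values shown sit. Among the compounds with values here, compound 2 and compound 3 share a different core from compound 1, so no single-point step among the measured compounds is available.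

Compound 4, `O=C(Nc1ccccc1O)C1c2ccccc2CCN1C(=O)c1ccc(Cl)cc1`, keeps the core of compound 1 and changes the amide substituent: 2-hydroxyphenyl in place of 4-(trifluoromethyl)phenyl on an amide-type nitrogen. Within the data shown here, no measured step of this kind exists among the three compounds, so the expectation for compound 4 rests on compound 1 alone and on the general observation that most values here are weak. The step of a 1.9-fold higher number from compound 1 to compound 4 (0.28 log units; within the scatter) is expected to be a modest loss, at the edge of the scatter, with a real chance that only a limit is reported. Compound 4 is therefore estimated at 8000 nM in this assay, within a range from 2500 nM to 20000 nM.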

Compound 4, concentration for 50% growth inhibition: > 10000 nM
Compound 4: only a limit was reported; the forecaster's own chance of this, stated with the estimate: 35%; middle value at least 1.2-fold (0.09 log units) away from the limit.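

In this assay, going by these compounds alone, this is the first single-place comparison on the shared core, and it shows that the amide substituent matters: the change to 2-hydroxyphenyl gives an at least 2.3-fold higher number from compound 1 to compound 4 (0.37 log units; beyond the scatter). As far as these compounds go, the value for compound 4 is a limit of the assay and not a number, so the step sets only a lower bound on the loss, and its full size stays unknown. Compound 1 remains the only compound with a measured number, and most of the series now sits at the same limit: the limit of > 10000 nM in this assay, at which 3 of the 4 values shown sit.

A single step cannot separate the loss of the 4-(trifluoromethyl)phenyl group from the entry of the 2-hydroxyphenyl group. From the compounds shown here alone, it also remains open how an aminophenyl group or a benzoic acid on the same amide-type nitrogen would read out in this assay.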